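Swapping the ring cap for methylsulfonyl on compound 3

This account rests on a few compounds, and the source may have more. Where it says the series, first, only, none or still open, it means among the compounds named here.

This series shares one core and differs in the group on the amine nitrogen of a small spiro ring. In a toxicity assay on MT4 cells (Homo sapiens) for cytotoxicity, read by MTT assay, with a stated time of 7 days (on this read-out higher numbers stand for lower toxicity in this test and lower numbers for higher toxicity in this test), compound 1 `Cc1cc(C)cc(S(=O)(=O)c2c(C(=O)NC3CC4(CCNC4)C3)[nH]c3ccc(Cl)cc23)c1` gives 25300 nM and compound 2 `Cc1cc(C)cc(S(=O)(=O)c2c(C(=O)NC3CC4(CNC4)C3)[nH]c3ccc(Cl)cc23)c1` gives 28600 nM; the step of a 1.1-fold higher number from compound 1 to compound 2 (0.05 log units; within the scatter) is small. Compound 3 `Cc1cc(C)cc(S(=O)(=O)c2c(C(=O)NC3CC4(C3)CN(Cc3n[nH]c(=O)n3C)C4)[nH]c3ccc(Cl)cc23)c1` gives 65600 nM in this assay, the highest of the three numbers, and the step of a 2.3-fold higher number from compound 2 to compound 3 (0.36 log units; beyond the scatter) is the one that set it apart. Compound 4 `Cc1cc(C)cc(S(=O)(=O)c2c(C(=O)NC3CC4(C3)CN(S(C)(=O)=O)C4)[nH]c3ccc(Cl)cc23)c1` carries the change (a group of 4 heavy atoms (1 carbon, 2 oxygen, 1 sulfur; no ring) in place of a group of 8 heavy atoms (4 carbon, 3 nitrogen, 1 oxygen; one five-membered aromatic ring with 3 hetero atoms), on an amine nitrogen in a ring). Among the measured compounds shown here, the only measured step that touches this position is the one from compound 2 to compound 3, where a large group entered on that nitrogen and the number rose modestly. Compound 4 keeps a substituent there, but a far smaller one, so its number is expected to fall between those of compound 2 and compound 3, giving an expected step of a 1.5-fold lower number from compound 3 to compound 4 (0.16 log units; within the scatter). Compound 4 is therefore estimated at 45000 nM, with a range from 22000 nM to 90000 nM.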

Compound 4, half-maximal cytotoxic concentration: > 233000 nM
Compound 4 ended at the assay's limit; the forecaster's own chance of this, stated with the estimate: 5%; at least 5.1-fold (0.71 log units) between middle value and limit.
By their numbers in this assay, from the lowest: compounds 1 and 2 (each within the scatter of the next); then compound 3. At a limit, above all of these: compound 4.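

In this assay compound 4 stands at a limit of the test, not at a number: the limit of > 233000 nM in this assay, at which 1 of the 4 values shown sits.

Among the compounds shown here, the earlier compounds showed only that a group on this amine nitrogen could raise the number modestly, whereas here the step of an at least 3.5-fold higher number from compound 3 to compound 4 (0.55 log units; beyond the scatter) goes to the group with fewer heavy atoms, so which group sits on the nitrogen matters, not just its atom count. Methylsulfonyl in place of hydrogen gives an at least 8.1-fold higher number from compound 2 to compound 4 (0.91 log units; beyond the scatter) and, with the change of spiro ring included, the comparison gives an at least 9.2-fold higher number from compound 1 to compound 4 (0.96 log units; beyond the scatter) as the widest gap in lower toxicity in this test.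

On these data alone, how far compound 4 really lies past its limit stays unknown. As far as these compounds go, an acetyl group or a plain methyl on the same nitrogen could show whether this rise is particular to methylsulfonyl, and the same group on the larger ring of compound 1 remains open.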